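The source may hold more compounds than are shown below. What is called first, only, known or untested is meant among the compounds shown, and "the series" means these compounds.

Measured so far in an assay on isolated protein for activation of Insulin-degrading enzyme (Homo sapiens), read by fluorescence, with stated times of 10 min and 20 min; on this read-out higher numbers stand for an effect only at larger amounts of compound and lower numbers for an effect already at smaller amounts:
compound 1 `CS(=O)(=O)n1cc(CCCC(=O)NCCCn2ccnc2)c2ccccc21`: 26900 nM
compound 2 `O=C(CCCc1cn(S(=O)(=O)c2ccc(F)cc2)c2ccccc12)NCCCn1ccnc1`: 6760 nM

Of these two numbers compound 2 has the lower one, set apart by a 4.0-fold lower number from compound 1 to compound 2 (0.60 log units; beyond the scatter). Compound 3 `O=C(CCCc1cn(S(=O)(=O)c2ccsc2)c2ccccc12)NCCCn1ccnc1` differs from compound 2 by thiophen-3-yl in place of 4-fluorophenyl on a sulfonyl sulfur. Going by the values given here, the only measured step that touches the same place, a 4.0-fold lower number from compound 1 to compound 2 (0.60 log units; beyond the scatter), was modest and exchanged a methyl for an aromatic ring, whereas here one aromatic ring stands in for another. A step of no more than modest size, in either direction, is therefore expected for a 1.2-fold higher number from compound 2 to compound 3 (0.07 log units; within the scatter). Compound 3 is estimated at 8000 nM, between 3000 nM and 20000 nM.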

Compound 3, half-maximal effective concentration: 13800 nM
Compound 3: the middle estimate sits 1.7-fold (0.24 log units) below what was measured, and the stated range covers the measured number.
By their numbers in this assay, from the lowest: compound 2; then compounds 3 and 1 (each within the scatter of the next).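

In this assay, one aromatic ring on a sulfonyl sulfur does not simply stand in for another: thiophen-3-yl in place of 4-fluorophenyl gives a 2.0-fold higher number from compound 2 to compound 3 (0.31 log units; beyond the scatter). Thiophen-3-yl in place of methyl gives a 1.9-fold lower number from compound 1 to compound 3 (0.29 log units; within the scatter), so an aromatic ring at this place does not alone carry the step beyond the scatter seen with 4-fluorophenyl. No supporting evidence bears on this difference. As far as these compounds go, it remains open how an unsubstituted phenyl or a pyridine ring on the sulfonyl sulfur would compare, and whether the fluorine itself contributes.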